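Changing the para group: outlook for compound 4

The source may report more compounds than this note shows. Statements on the series, on what has been measured and on what is new or still open speak of the compounds shown alone.

Three compounds share one core and differ only in the group on an aromatic nitrogen. In an ADME assay on L6 cells (Rattus norvegicus) for cytotoxicity, read by resazurin assay, with a stated time of 72 h (a higher number here means that more compound is needed for the effect, a lower number that less compound is needed), compound 1 `CCOC(=O)C1=C(C)N/C(=C/c2cc(C)n(-c3cccc(C(F)(F)F)c3)c2C)C1=O` gives 100000 nM, compound 2 `CCOC(=O)C1=C(C)N/C(=C/c2cc(C)n(-c3ccc(N(C)C)cc3)c2C)C1=O` gives 180000 nM, and compound 3 `CCOC(=O)C1=C(C)N/C(=C/c2cc(C)n(-c3cccnc3)c2C)C1=O` gives 160000 nM. Compound 2 sits at the upper end of these numbers, yet a 1.8-fold higher number from compound 1 to compound 2 (0.26 log units; within the scatter) and a 1.1-fold lower number from compound 2 to compound 3 (0.05 log units; within the scatter) are both within the scatter, as is a 1.6-fold higher number from compound 1 to compound 3 (0.20 log units; within the scatter). Compound 4 `CCOC(=O)C1=C(C)N/C(=C/c2cc(C)n(-c3ccc(CN4CCCCC4)cc3)c2C)C1=O` differs from compound 2 by (piperidin-1-yl)methyl in place of dimethylamino on an aromatic carbon. Among the compounds with values here, no measured step touches that position; all three steps are small and concern the aromatic nitrogen. The expected step in this assay is therefore a 1.2-fold lower number from compound 2 to compound 4 (0.08 log units; within the scatter), nothing beyond the scatter. Compound 4 is estimated at 150000 nM, within a range from 50000 nM to 300000 nM.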

Compound 4, half-maximal effective concentration: 81000 nM
Compound 4: middle estimate off by 1.9-fold (0.27 log units), on the high side, and the stated range covers the measured number.
By their numbers in this assay, from the lowest: compounds 4, 1, 3 and 2 (each within the scatter of the next, the first and the last beyond it).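

In this assay, within the data shown here, (piperidin-1-yl)methyl in place of dimethylamino gives a 2.2-fold lower number from compound 2 to compound 4 (0.35 log units; beyond the scatter) and is the only step in this set that lies beyond the scatter. Among these compounds, the earlier steps all concerned the group on the aromatic nitrogen, so this is the first sign that the group on the aromatic carbon can move the number, though only modestly. No measurement shown here explains this shift. The compounds shown cannot separate the contribution of the piperidine ring from that of the added methylene carbon. A (dimethylamino)methyl group or a (morpholin-4-yl)methyl group at this place would help to tell them apart.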